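Swapping One Oxadiazole Isomer for Another

A few compounds are considered here, and "the series" means these few. Any claim that something is new, unique, unknown or untested is made for them only; others in the source may bear on it.

Of the compounds shown here, two sharing one core have been measured in an assay on HEK-Blue hNOD1 cells for antagonist activity at Nucleotide-binding oligomerization domain-containing protein 1 (Homo sapiens), read by reporter gene assay, with stated times of 3 h and 20 h; a lower number here means a stronger inhibitor, a higher number a weaker inhibitor. Compound 1 `CCCCOC(=O)CC1c2cccc(C)c2S(=O)(=O)N1C(=O)c1cccc(C(F)(F)F)c1` gives 1050 nM, and compound 2 `CCCCc1noc(CC2c3cccc(C)c3S(=O)(=O)N2C(=O)c2cccc(C(F)(F)F)c2)n1` gives 230 nM. Among the measured compounds shown here, the single measured step is a 4.6-fold lower number from compound 1 to compound 2 (0.66 log units; beyond the scatter). For the measured compounds named here, compound 2 therefore stands at the lower of the two numbers, with compound 1 as its only neighbour at a higher number beyond the scatter.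

Compound 3 `CCCCc1nnc(CC2c3cccc(C)c3S(=O)(=O)N2C(=O)c2cccc(C(F)(F)F)c2)o1` has not yet been measured. It differs from compound 2 by 5-butyl-1,3,4-oxadiazol-2-yl in place of 3-butyl-1,2,4-oxadiazol-5-yl on a saturated chain carbon bound to a saturated ring carbon: the two have the same atoms, joined differently, so only the arrangement within the five-membered ring changes. Going by the values given here, no measured step bears directly on this kind of change; the only known step, a 4.6-fold lower number from compound 1 to compound 2 (0.66 log units; beyond the scatter), concerns the exchange of the butoxycarbonyl group for the ring itself, not the pattern inside the ring, and offers no guide to direction. A step of modest size at most is therefore expected, with no direction the data can support, and a 1.5-fold higher number from compound 2 to compound 3 (0.18 log units; within the scatter) is the expected outcome. Compound 3 is thus estimated at 350 nM, between 120 nM and 1000 nM.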

Compound 3, half-maximal inhibitory concentration: 1740 nM
For compound 3 the middle estimate is 5.0-fold (0.70 log units) below the measured one; measured number above the stated range.
By their numbers in this assay, from the lowest: compound 2; then compounds 1 and 3 (each within the scatter of the next).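

In this assay, this position on a saturated chain carbon bound to a saturated ring carbon proves sensitive to the arrangement within the five-membered ring alone: the two groups have the same atoms and the same counts of hydrogen-bond donors and acceptors, yet the isomer exchange gives a 7.6-fold higher number from compound 2 to compound 3 (0.88 log units; beyond the scatter). The lower number of compound 2 therefore does not extend to both oxadiazole isomers shown, for a 1.7-fold higher number from compound 1 to compound 3 (0.22 log units; within the scatter) lies within the scatter, leaving 5-butyl-1,3,4-oxadiazol-2-yl and butoxycarbonyl indistinguishable in this assay. Nothing available explains why the two ring arrangements differ.

The compounds shown leave open whether the third arrangement, 5-butyl-1,2,4-oxadiazol-3-yl, would align with compound 2 or with compound 3, and whether a shorter chain or a phenyl group in place of butyl on the 1,2,4-oxadiazole would keep the lower number. They also leave open whether the gap between the two isomers would persist if the trifluoromethyl group on the shared core were replaced, for example by a chlorine atom.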